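A tertiary amide variant on a thienopyrimidine cAMP agonist series

The compounds below may be only part of what the source reports. "The series", "measured", "known", "first", "only" and "open" are said of these compounds alone.

Compound 3 `CCNC(=O)c1sc2nc(SC)nc(-c3cccc(OC)c3)c2c1N` has no reported number in a functional assay on HEK293 cells for agonist activity at lutropin-choriogonadotropic hormone receptor (Homo sapiens), read by cAMP accumulation (on this read-out higher numbers stand for an effect only at larger amounts of compound and lower numbers for an effect already at smaller amounts), where compound 3 is recorded as "not determined" (no result reported), so it stands nowhere on the scale yet. Compound 4 `COc1cccc(-c2nc(SC)nc3sc(C(=O)N(C)C(C)(C)C)c(N)c23)c1` differs from it in one place: methyl(tert-butyl)amino in place of ethylamino on a carbonyl carbon. Two related compounds give a sense of the range. Compound 1 `COc1cccc(-c2nc(SC)nc3sc(C(=O)NC(C)(C)C)c(N)c23)c1F` gives 1500 nM in this assay, and compound 2 `COc1cccc(-c2nc(SC)nc3sc(C(=O)NC(C)(C)C)c(N)c23)c1OC` gives 800 nM; the step between them, a 1.9-fold lower number from compound 1 to compound 2 (0.27 log units; within the scatter), concerns a ring substituent and not the amide, so it does not bear directly on the change from compound 3 to compound 4. Within the data shown here, with no measured step touching the amide, no direction can be called, and the estimate must be broad. Compound 4 is expected to give about 2000 nM, with a range from 400 nM to 10000 nM.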

Compound 4, half-maximal effective concentration: 800 nM
Compound 4: middle estimate off by 2.5-fold (0.40 log units), on the high side; the measured number falls inside the stated range.
By their numbers in this assay, from the lowest: compounds 2, 4 and 1 (each within the scatter of the next).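

Compound 3 has no number to set against compound 4, so no step can be read from this result. On these data alone, what the change from ethylamino to methyl(tert-butyl)amino does to the read-out stays open. No evidence shown bears on the value of compound 4.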